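This account rests on a few compounds, and the source may have more. Where it says the series, first, only, none or still open, it means among the compounds named here.

Working notes on the series, read in a functional assay on KYSE-450 cells (Homo sapiens) for inhibition, read by CCK-8 assay, with a stated time of 48 h; a lower number here means a stronger inhibitor, a higher number a weaker inhibitor. Compound 1 `COc1ccc(CN(C(=O)CSC(=S)N2CCN(C(=O)OC(C)(C)C)CC2)c2cc(OC)c(OC)c(OC)c2)cc1F` gives 2410 nM, and compound 2 `COc1ccc(CN(C(=O)CSC(=S)N2CCN(C(=O)OC(C)(C)C)CC2)c2cc(OC)c(OC)c(OC)c2)cc1Br` gives 1850 nM. These two values lie within the scatter of each other, so compound 2 stands level with compound 1 and the pair sets no ranking. The next analogue is compound 3 `COc1ccc(CN(C(=O)CSC(=S)N2CCN(C(=O)OC(C)(C)C)CC2)c2cc(OC)c(OC)c(OC)c2)cc1C`, and the change is methyl in place of bromo on an aromatic carbon, turning 3-bromo-4-methoxybenzyl into 4-methoxy-3-methylbenzyl. Among the measured compounds shown here, no measured compound carries a methyl at this place, so the data give no direct reading on that group. For the measured compounds named here, the one measured step that bears on the change is a 1.3-fold lower number from compound 1 to compound 2 (0.11 log units; within the scatter), bromo in place of fluoro on the same aromatic carbon, and on that step alone no shift beyond the scatter is expected in this assay, in either direction. The expected step is a 1.1-fold higher number from compound 2 to compound 3 (0.03 log units; within the scatter). For compound 3 the estimated value is 2000 nM, with an expected range of 900 nM to 4500 nM.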

Compound 3, half-maximal inhibitory concentration: > 20000 nM
Compound 3 gave a limit, no number (the forecaster's own chance of this, stated with the estimate: 2%); middle value at least 10-fold (1.00 log units) away from the limit.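

Compound 3 stands at a limit of the assay, not at a number: the limit of > 20000 nM in this assay, at which 1 of the 3 values shown sits. In this assay, methyl in place of bromo gives an at least 10-fold higher number from compound 2 to compound 3 (1.03 log units; beyond the scatter), and methyl in place of fluoro gives an at least 8.2-fold higher number from compound 1 to compound 3 (0.91 log units; beyond the scatter), so this aromatic carbon, ortho to a methoxy group, is not indifferent to what it carries, which a 1.3-fold lower number from compound 1 to compound 2 (0.11 log units; within the scatter) gave no sign of. Among these three compounds, the two halogen analogues, compound 1 and compound 2, both return a measured value while the methyl analogue, compound 3, does not, even though each change swaps one heavy atom for one heavy atom and adds no ring, donor, acceptor or charge.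

The compounds shown do not tell what separates methyl from fluoro and bromo, and the loss is read here from a single methyl analogue on a single background. From the compounds shown here alone, whether chloro, ethyl, trifluoromethyl, hydroxyl or an amine at this carbon would sit with the halogens or with methyl remains open, as does whether the same change would carry the same penalty with a different group in place of the tert-butyl carbamate.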